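A Nitrile Gives Way to a Methyl on the Pendant Ring

The compounds below may be only part of what the source reports. "The series", "measured", "known", "first", "only" and "open" are said of these compounds alone.

Among the compounds with values here, compound 2 `CC/C(=C(/c1ccc(/C=C/C(=O)O)cc1)c1cc2ccccc2[nH]1)c1ccc(Cl)cc1C#N` gives 14 nM in a functional assay on MCF7 cells (Homo sapiens) for inhibition (on this read-out higher numbers stand for weaker inhibition and lower numbers for stronger inhibition), the highest of the two numbers so far, while compound 1 `CC/C(=C(/c1ccc(/C=C/C(=O)O)cc1)c1cc2ccccc2[nH]1)c1ccccc1C(F)(F)F` gives 8 nM; the step of a 1.8-fold higher number from compound 1 to compound 2 (0.24 log units; within the scatter) lies within the scatter, so no order between these two compounds can be claimed. Compound 3 `CC/C(=C(/c1ccc(/C=C/C(=O)O)cc1)c1cc2ccccc2[nH]1)c1ccc(Cl)c(C)c1` has not yet been measured. It differs from compound 2 in one place: 4-chloro-3-methylphenyl in place of 4-chloro-2-cyanophenyl on a double-bonded chain carbon bound to a double-bonded chain carbon and a saturated chain carbon. Within the data shown here, the only measured step that bears on this position is a 1.8-fold higher number from compound 1 to compound 2 (0.24 log units; within the scatter), which exchanged one substituted phenyl for another and shifted the number by an amount within the scatter. On that basis a step of a 1.2-fold lower number from compound 2 to compound 3 (0.07 log units; within the scatter) is expected in this assay, that is, no change beyond the scatter. Compound 3 is therefore estimated at 12 nM, with a range from 5 nM to 35 nM.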

Compound 3, half-maximal inhibitory concentration: 840 nM
Compound 3: middle estimate off by 70-fold (1.85 log units), on the low side; measured number outside the range, above it.
By their numbers in this assay, from the lowest: compounds 1 and 2 (each within the scatter of the next); then compound 3.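

In this assay, 4-chloro-3-methylphenyl in place of 4-chloro-2-cyanophenyl gives a 60-fold higher number from compound 2 to compound 3 (1.78 log units; beyond the scatter) on the double-bonded chain carbon, so this position does not take every substituted phenyl alike, which the earlier pair, within the scatter of each other, could not show. The same ring in place of 2-(trifluoromethyl)phenyl gives a 110-fold higher number from compound 1 to compound 3 (2.02 log units; beyond the scatter) in the same direction, and of the three rings it alone carries neither a nitrile nor a trifluoromethyl group. Nothing available accounts for the size of these steps.

Compound 3 loses the nitrile and gains the methyl in one change, so the shares of the two cannot be told apart. From the compounds shown here alone, how a plain 4-chlorophenyl, or a ring bearing a methoxy group or an amine instead of the methyl, would stand remains open.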